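A few compounds are considered here, and "the series" means these few. Any claim that something is new, unique, unknown or untested is made for them only; others in the source may bear on it.

Working notes on the series. Compound 1 `COc1cccc(-c2nc(SC)nc3sc(C(=O)NCCO)c(N)c23)c1` has a result of "not determined" (no result reported) in a functional assay on HEK293 cells for agonist activity at lutropin-choriogonadotropic hormone receptor (Homo sapiens), read by cAMP accumulation (a lower number here means that less compound is needed, a higher number that more compound is needed for the effect), so it stands nowhere on the numbers. Going by the values given here, the only measured member, compound 2 `CSc1nc(-c2cccc(O)c2)c2c(N)c(C(=O)NC(C)(C)C)sc2n1`, gives 1900 nM in this assay. Compound 3 `COc1cccc(-c2nc(SC)nc3sc(C(=O)N(C)C(C)(C)C)c(N)c23)c1` differs from compound 1 by one change: methyl(tert-butyl)amino in place of (2-hydroxyethyl)amino on a carbonyl carbon. Among the compounds with values here, with no measured pair bracketing this change, its direction in this assay cannot be inferred; a step of some size beyond the scatter, in either direction, is plausible, as is none. The expected value for compound 3 in this assay is 3000 nM, with a range of 500 nM to 20000 nM.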

Compound 3, half-maximal effective concentration: 800 nM
Beside the measured number, compound 3's estimate is 3.8-fold (0.57 log units) above it; the range from low to high includes it.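

In this assay, going by these compounds alone, compound 1 has no number, so no step to compound 3 can be read. From the compounds shown here alone, whether (2-hydroxyethyl)carbamoyl to methyl(tert-butyl)carbamoyl shifts the response, and in which direction, stays open. No evidence bears on this result.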